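This account rests on a few compounds, and the source may have more. Where it says the series, first, only, none or still open, it means among the compounds named here.

In a functional assay on NALM-6 cells (Homo sapiens) for cytotoxicity, read by MTT assay, with a stated time of 48 h (on this read-out lower numbers stand for stronger inhibition and higher numbers for weaker inhibition), compound 2, with the structure `O=c1c(/C=N/Nc2cc(Cl)ccc2Cl)coc2ccccc12`, gives 85300 nM. Compound 1, with the structure `Cc1cc2oc(N)c(/C=N/NCCO)c(=O)c2cc1C`, gives 65300 nM in this assay; the two numbers lie within the usual scatter of each other, so neither compound can be set apart from the other on these data. Compound 3, with the structure `Nc1oc2ccccc2c(=O)c1/C=N/Nc1cc(Cl)ccc1Cl`, is not yet measured. It differs from compound 2 in one place: amino in place of hydrogen on an aromatic carbon. Among the measured compounds shown here, no measured pair shows this change on its own. Compound 1 carries an amino group at the same kind of position and gives a number close to that of compound 2, so the step from compound 2 to compound 3 is expected to be a 1.4-fold lower number from compound 2 to compound 3 (0.15 log units; within the scatter), not beyond the scatter. Compound 3 is therefore expected to give about 60000 nM in this assay, with a plausible range from 25000 nM to 150000 nM.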

Compound 3, half-maximal inhibitory concentration: 500000 nM
Estimate against measurement, compound 3: 8.3-fold (0.92 log units) below; measured number above the stated range.
By their numbers in this assay, from the lowest: compounds 1 and 2 (each within the scatter of the next); then compound 3.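

In this assay, amino in place of hydrogen on the aromatic carbon next to the ring oxygen gives a 5.9-fold higher number from compound 2 to compound 3 (0.77 log units; beyond the scatter), so here this single change weakens inhibition by more than the usual scatter. Among the compounds shown here, this is the first pair to show the change on its own. Compound 1 also carries an amino group at this kind of position, but it differs from compound 3 in other places as well, so it could not show what amino alone does.

Going by these compounds, it remains open whether a methoxy group or a fluorine atom on this carbon would also weaken inhibition, and whether amino would have the same effect on the core of compound 1. No measurement shown gives a reason for this step.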